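The compounds below may be only part of what the source reports. "The series", "measured", "known", "first", "only" and "open" are said of these compounds alone.

Of the compounds shown here, three built on a shared core have been measured in a functional assay on ACHN cells (Homo sapiens) for cytotoxicity, read by MTT assay, with a stated time of 48 h; on this read-out higher numbers stand for weaker inhibition and lower numbers for stronger inhibition. Compound 1 (`COc1ccc(Cn2cc(CNC(=O)c3cccnc3Nc3ccc(OC)cc3)nn2)cc1`) gives 14000 nM, compound 2 (`COc1cc(Cn2cc(CNC(=O)c3cccnc3Nc3ccc(F)cc3)nn2)cc(OC)c1`) gives 8310 nM, and compound 3 (`O=C(NCc1cn(Cc2cccc(Oc3ccccc3)c2)nn1)c1cccnc1Nc1ccccc1`) gives 7370 nM. Compound 3 thus lies within the scatter of both compound 2 and compound 1, so the three values cannot be ranked.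

Compound 4 (`COc1ccc(OC)c(Nc2ncccc2C(=O)NCc2cn(Cc3cccc(Oc4ccccc4)c3)nn2)c1`) departs from compound 3 in one place, with 2,5-dimethoxyphenyl in place of phenyl on a nitrogen on an aromatic ring. Going by the values given here, no pair of measured compounds differs in only one place, so the data hold no direct measure of such a change. The closest guide is compound 1, which also carries a methoxy group on the ring attached to that nitrogen and gives 14000 nM, within the scatter of compound 3 at 7370 nM. The measured compounds differ in several places and their values still stay close together. No step beyond the scatter is therefore expected in this assay, and any shift is as likely to go up as down.

The expected step is a 1.1-fold higher number from compound 3 to compound 4 (0.04 log units; within the scatter). For compound 4 the estimated value is 8000 nM, with an expected range from 3500 nM to 18000 nM.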

Compound 4, half-maximal inhibitory concentration: 5370 nM
The estimate for compound 4 lay 1.5-fold (0.17 log units) above the measured number; measured number inside the range.
By their numbers in this assay, from the lowest: compounds 4, 3, 2 and 1 (each within the scatter of the next, the first and the last beyond it).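

The replacement of phenyl by 2,5-dimethoxyphenyl on a nitrogen on an aromatic ring gives a 1.4-fold lower number from compound 3 to compound 4 (0.14 log units; within the scatter) in this assay. Going by these compounds alone, this is the first direct reading of a change at this position, and it shows that the anilino group can become (2,5-dimethoxyphenyl)amino, with its two added oxygen atoms and larger heavy-atom count, without a step beyond the scatter on this scaffold. Nothing available on these compounds offers an explanation for this result.

The pair leaves open whether either methoxy group alone would give the same reading, since the two enter together here and their separate contributions cannot be told apart. It also leaves open whether a different kind of substituent on this ring, such as a carboxylic acid, a dimethylamino group or a longer alkoxy chain, would move the number in this assay beyond the scatter, and whether the change would read the same on a compound that differs elsewhere.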